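This account rests on a few compounds, and the source may have more. Where it says the series, first, only, none or still open, it means among the compounds named here.

In a functional assay on SH-SY5Y cells (Homo sapiens) for antagonist activity, read by cAMP accumulation (on this read-out higher numbers stand for higher potency (the scale is a negative logarithm) and lower numbers for lower potency), compound 1 `CCOc1ccc(Cc2ccc(NC3=NCCN3)cc2)cc1` gives 8.2, and compound 2 `CC(C)COc1ccc(Cc2ccc(NC3=NCCN3)cc2)cc1` gives 8.8, the higher of the two numbers, separated by a number 0.60 log units higher from compound 1 to compound 2 (beyond the scatter). Compound 3 `FC(F)(F)COc1ccc(Cc2ccc(NC3=NCCN3)cc2)cc1` differs from compound 2 by trifluoromethyl in place of isopropyl on a saturated chain carbon bound to an oxygen on an aromatic ring. Among the compounds with values here, the one measured step sits at the same saturated chain carbon bound to an oxygen on an aromatic ring and rose when isopropyl replaced methyl; no measured step brings in fluorine, so it bears only loosely on this change. The step of a number 0.50 log units lower from compound 2 to compound 3 (beyond the scatter) in this assay is expected to be modest and downward. Compound 3 is estimated at 8.3, within 7.7 to 8.9.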

Compound 3, negative logarithm of the antagonist equilibrium constant: 8.7
Beside the measured number, compound 3's estimate is 0.40 log units below it; measured number inside the range.
By their numbers in this assay, from the lowest: compound 1; then compounds 3 and 2 (each within the scatter of the next).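

In this assay, a number 0.10 log units lower from compound 2 to compound 3 (within the scatter) at this saturated chain carbon bound to an oxygen on an aromatic ring, so trifluoromethyl and isopropyl cannot be told apart here. Trifluoromethyl also keeps a gain over methyl, with a number 0.50 log units higher from compound 1 to compound 3 (beyond the scatter) in the same assay, so among these compounds the rise over methyl is not unique to isopropyl. No supporting data explain this match between the two groups. Still open, as far as these compounds go, is how a longer chain, an amine or a carboxylic acid would fare at this place. How far the number tracks the group's size also remains unresolved with only these compounds.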